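The source may report more compounds than this note shows. Statements on the series, on what has been measured and on what is new or still open speak of the compounds shown alone.

In a functional assay on MCF7 cells (Homo sapiens) for cytotoxicity, read by MTT assay, with a stated time of 24 h (a higher number here means a weaker inhibitor, a lower number a stronger inhibitor), compound 1 `CCNc1cc(-c2ccc(NC(=O)Nc3ccc(OC)cc3)cc2C)ccn1` gives 9950 nM, compound 2 `CCNc1cc(-c2ccc(NC(=O)Nc3cccc4ccccc34)cc2C)ccn1` gives 15500 nM and compound 3 `CCNc1cc(-c2ccc(NC(=O)Nc3c(C)cccc3C)cc2C)ccn1` gives 7920 nM. Compound 1 stands level with the other two within the scatter, as a 1.6-fold higher number from compound 1 to compound 2 (0.19 log units; within the scatter) and a 1.3-fold lower number from compound 1 to compound 3 (0.10 log units; within the scatter) show; a 2.0-fold lower number from compound 2 to compound 3 (0.29 log units; within the scatter) also stays within it. Compound 4 `CCNc1cc(-c2ccc(NC(=O)Nc3ccc(OC)cc3)cc2C(F)(F)F)ccn1` differs from compound 1 in one place: trifluoromethyl in place of methyl on an aromatic carbon. All three measured steps exchange the group on an amide-type nitrogen, so none tests this place, and they bear on it only indirectly. No step beyond the scatter is therefore expected in this assay. The estimated outcome is a 1.2-fold lower number from compound 1 to compound 4 (0.07 log units; within the scatter). Compound 4 is expected at 8500 nM, with an estimated range from 3800 nM to 19000 nM.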

Compound 4, half-maximal inhibitory concentration: 5740 nM
Compound 4: the middle estimate sits 1.5-fold (0.17 log units) above what was measured, within the range that was stated.
By their numbers in this assay, from the lowest: compounds 4, 3, 1 and 2 (each within the scatter of the next, the first and the last beyond it).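

In this assay, trifluoromethyl in place of methyl on the aromatic carbon ortho to the 2-(ethylamino)pyridin-4-yl group gives a 1.7-fold lower number from compound 1 to compound 4 (0.24 log units; within the scatter), the only step shown at this position. The position therefore takes a group of 4 heavy atoms in place of 1 without a step beyond the scatter. No measurement on hand offers an explanation for this result. On these data alone, what an ethyl group, a chlorine atom or a methoxy group would do at this position remains open. So does whether trifluoromethyl gives a similar step alongside naphthalen-1-yl or 2,6-dimethylphenyl on the amide-type nitrogen.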